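Notes on the 3-oxopiperazin-1-yl change

A few compounds are considered here, and "the series" means these few. Any claim that something is new, unique, unknown or untested is made for them only; others in the source may bear on it.

In a physicochemical assay for solubility, read by HPLC, in phosphate buffer, at pH 6.5 (on this read-out higher numbers stand for higher solubility and lower numbers for lower solubility), compound 1 (`COC(=O)C1=C(C)NC(c2nccs2)=NC1(C)c1ccc(Cl)cc1`) gives 14 ug/mL and compound 2 (`COC(=O)C1=C(C)NC(c2nccs2)=NC1(C)c1ccc(OC)cc1`) gives 106 ug/mL while compound 3 (`COC(=O)C1=C(CN2CCNCC2)NC(c2nccs2)=NC1(C)c1ccc(F)cc1`) gives 250 ug/mL as the highest of the three numbers, beyond the scatter from both others. Among the compounds with values here, compound 4 (`COC(=O)C1=C(CN2CCNC(=O)C2)NC(c2nccs2)=NC1(C)c1ccc(F)cc1`) is still unmeasured and differs from compound 3 as follows: 3-oxopiperazin-1-yl in place of piperazin-1-yl on a saturated chain carbon bound to a double-bonded ring carbon at a place no measured step touches. Within the data shown here, the single measured step (a 7.6-fold higher number from compound 1 to compound 2 (0.88 log units; beyond the scatter)) is methoxy in place of chloro on an aromatic carbon, so it offers only a scale of size. The direction rests on the structural change alone. A lower number is expected in this assay with an estimated step (a 2.5-fold lower number from compound 3 to compound 4 (0.40 log units; beyond the scatter)) smaller than that scale. For compound 4 the estimate is 100 ug/mL within an expected range from 35 ug/mL to 260 ug/mL on this read-out.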

Compound 4, solubility: 34 ug/mL
Compound 4: the middle estimate sits 2.9-fold (0.47 log units) above what was measured; measured number below the stated range.
By their numbers in this assay, from the lowest: compound 1; then compound 4; then compound 2; then compound 3.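

Within the data shown here, at the saturated chain carbon bound to a double-bonded ring carbon, 3-oxopiperazin-1-yl in place of piperazin-1-yl gives a 7.4-fold lower number from compound 3 to compound 4 (0.87 log units; beyond the scatter) in this assay, the first sign that a change at this position can move the read-out beyond the scatter. The two groups have the same hydrogen-bond donor and acceptor counts and no net charge, so those counts do not track the step. Nothing available bears on what lies behind it.

From the compounds shown here alone, whether morpholine or an open-chain amine at this place would read closer to compound 3 or compound 4 stays open, as does whether the step holds with the chloro or methoxy group of compound 1 and compound 2 in place of the fluoro group.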